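Fluoro-methoxyphenyl in place of trimethoxyphenyl on the enaminone

The source may report more compounds than this note shows. Statements on the series, on what has been measured and on what is new or still open speak of the compounds shown alone.

Three enaminone compounds sharing a benzothiazole-bearing aniline were tested in a functional assay on MIA PaCa-2 cells (Homo sapiens) for antiproliferative activity, read by sulforhodamine B assay, with a stated time of 48 h; a higher number here means a weaker inhibitor, a lower number a stronger inhibitor. Compound 1 `COc1cc(C(=O)/C=C\Nc2ccc(-c3nc4cc(OC)c(OC)c(OC)c4s3)cc2)c(Br)c(OC)c1OC` gives 23200 nM. Compound 2 `COc1cc(OC)c2sc(-c3ccc(N/C=C\C(=O)c4cc(OC)c(OC)c(OC)c4)cc3)nc2c1` gives 26800 nM. Compound 3 `COc1ccc2nc(-c3ccc(N/C=C\C(=O)c4ccc(OC)c([N+](=O)[O-])c4)c(C)c3)sc2c1` gives 23600 nM. Compound 2 carries the highest of the three numbers, yet its gap to compound 3 and its gap to compound 1 both lie within the scatter of this assay, so no order among the three can be read from these values.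

Compound 4 `COc1cc(OC)c2sc(-c3ccc(N/C=C\C(=O)c4ccc(OC)c(F)c4)cc3)nc2c1` has not yet been measured. It differs from compound 2 in one place: 3-fluoro-4-methoxyphenyl in place of 3,4,5-trimethoxyphenyl on a carbonyl carbon. Going by the values given here, no measured pair shows the effect of such a change, and compound 3, which carries a different aryl group on the same carbonyl carbon, gives a number close to that of compound 2.

On that basis the step from compound 2 to compound 4 is expected to be small, a 1.1-fold lower number from compound 2 to compound 4 (0.03 log units; within the scatter), with no change beyond the scatter. Compound 4 is accordingly estimated at 25000 nM in this assay, within a range from 10000 nM to 60000 nM.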

Compound 4, half-maximal inhibitory concentration: 4300 nM
Beside the measured number, compound 4's estimate is 5.8-fold (0.76 log units) above it; measured number outside the range, below it.
By their numbers in this assay, from the lowest: compound 4; then compounds 1, 3 and 2 (each within the scatter of the next).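

In this assay, the aryl group on the carbonyl carbon proves to be a place where the number can move: 3-fluoro-4-methoxyphenyl in place of 3,4,5-trimethoxyphenyl gives a 6.2-fold lower number from compound 2 to compound 4 (0.79 log units; beyond the scatter), a modest step beyond the scatter. The earlier compounds shown here included no pair differing in one place, so they could not show this. The entering group has fewer heavy atoms and fewer hydrogen-bond acceptors than the group that leaves, but nothing available accounts for the step.

This single pair cannot separate the gain of fluorine from the loss of methoxy groups, and it leaves open whether a chlorine or an amine in place of that fluorine would give a similar number. On these data alone, whether the step carries over to the cores of compound 1 and compound 3 also remains open.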